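The source may hold more compounds than are shown below. What is called first, only, known or untested is meant among the compounds shown, and "the series" means these compounds.

Measured compounds in the series:

- compound 1, `Cn1c(=O)c(S(=O)(=O)c2ccc([N+](=O)[O-])cc2F)cc2cnc(Nc3ccc4[nH]ccc4c3)nc21`: 400 nM
- compound 2, `COc1ccc(Nc2ncc3cc(S(=O)(=O)c4ccc(C)cc4)c(=O)n(C)c3n2)cc1`: 100000 nM
- compound 3, `Cn1c(=O)c(S(=O)(=O)c2ccc(OC(=O)CCCCC3SCC4NC(=O)NC43)cc2)cc2cnc(Nc3ccc4[nH]ccc4c3)nc21`: 150 nM

All three were run in a functional assay on DU-145 cells (Homo sapiens) for inhibition, read by trypan blue exclusion, with a stated time of 72 h; a lower number here means a stronger inhibitor, a higher number a weaker inhibitor. Compound 1 stands second highest of the three numbers. Its nearest neighbour is compound 3, whose number is lower and whose gap to compound 1 lies beyond the scatter. Its furthest neighbour is compound 2, whose number is far higher, again beyond the scatter. Compound 2 differs from compound 1 in more than one place, so what its values show cannot be tied to any single group.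

The step under consideration leads from compound 1 to compound 4, `Cn1c(=O)c(S(=O)(=O)c2ccc(Br)cc2)cc2cnc(Nc3ccc4[nH]ccc4c3)nc21`, which has not yet been measured in this assay. The change sits on the sulfonyl sulfur: 4-bromophenyl in place of 2-fluoro-4-nitrophenyl on a sulfonyl sulfur.

Within the data shown here, no pair of measured compounds differing only at this position is available, so the size of the step has to be guessed. Among the measured compounds shown here, the shared core and the indole-bearing amine of compound 1 are kept in compound 4, and the only change is in the ring on the sulfonyl sulfur. A small to moderate step toward a higher number in this assay is expected, with a real chance of no change beyond the scatter. Compound 4 is therefore estimated at 800 nM, within 250 nM to 3000 nM, which corresponds to an expected step of a 2.0-fold higher number from compound 1 to compound 4 (0.30 log units; within the scatter).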

Compound 4, half-maximal inhibitory concentration: 5000 nM
The estimate for compound 4 lay 6.3-fold (0.80 log units) below the measured number; measured number above the stated range.
By their numbers in this assay, from the lowest: compound 3; then compound 1; then compound 4; then compound 2.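

In this assay, the group on the sulfonyl sulfur is now the first place in the series where a single change can be read: a 13-fold higher number from compound 1 to compound 4 (1.10 log units; beyond the scatter), with the rest of compound 1 kept, so this position is far from indifferent to what it carries. Compound 4 and compound 3 differ only in the group on that same ring, and their printed values, compound 4 at 5000 nM and compound 3 at 150 nM, show the same wide sensitivity on a second pair. No measurement at hand bears on why the 4-bromophenyl compound lies so much higher, so the step stands as an observation only.

Going by these compounds, the step exchanges several features at once, so it remains open whether the loss follows the absence of the nitro group, the absence of the fluorine, or the presence of the bromine; a phenyl carrying only the nitro group or only the fluorine would separate these. Also open, on these data alone, is how an amine or a carboxylic acid on this ring would read in this assay.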